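One Ring Change Tested Across Two Related Cores

The source may report more compounds than this note shows. Statements on the series, on what has been measured and on what is new or still open speak of the compounds shown alone.

Compound 1 `NS(=O)(=O)c1ccc(-n2nc(-c3ccc(Cl)cc3)cc2-c2cc(O)ccc2O)cc1` and compound 3 `NS(=O)(=O)c1ccc(-n2nc(-c3ccc(Cl)cc3)cc2C2=CC(=O)C=CC2=O)cc1` share a core and differ in one place only. Compound 2 `CC(=O)NS(=O)(=O)c1ccc(-n2nc(-c3ccccc3)cc2-c2cc(O)ccc2O)cc1` and the not yet measured compound 4 `CC(=O)NS(=O)(=O)c1ccc(-n2nc(-c3ccccc3)cc2C2=CC(=O)C=CC2=O)cc1` form a second pair carrying the same kind of change. The difference between the two cores is not broken down here.

In a functional assay on cells (Cancer cell lines, Homo sapiens) for cytotoxicity, read by sulforhodamine B assay, with a stated time of 48 h (a lower number here means a stronger inhibitor of growth, a higher number a weaker inhibitor of growth), compound 1 gives 13000 nM. In this assay compound 3 gives 23900 nM. The step of a 1.8-fold higher number from compound 1 to compound 3 (0.26 log units; within the scatter) goes with the change (a group of 8 heavy atoms (6 carbon, 2 oxygen; one six-membered non-aromatic ring of carbon only) in place of a group of 8 heavy atoms (6 carbon, 2 oxygen; one six-membered aromatic ring of carbon only), on an aromatic carbon). In this assay compound 2 gives 93900 nM, the highest of the three measured numbers and beyond the scatter from both others. The change that leads to compound 4 is a group of 8 heavy atoms (6 carbon, 2 oxygen; one six-membered non-aromatic ring of carbon only) in place of a group of 8 heavy atoms (6 carbon, 2 oxygen; one six-membered aromatic ring of carbon only), on an aromatic carbon. Around the place, the two pairs are not identical: in the first pair the neighbouring ring atom bears a 4-sulfamoylphenyl group and the atom two ring bonds away bears a 4-chlorophenyl group, while in the second pair the neighbouring ring atom bears a large group and the atom two ring bonds away bears a phenyl group. It is therefore the same kind of change, not the same change.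

Because a 1.8-fold higher number from compound 1 to compound 3 (0.26 log units; within the scatter) lay within the scatter, the change is expected to move the number only a little. Resting on that measured step, the expected step is a 1.7-fold higher number from compound 2 to compound 4 (0.23 log units; within the scatter). Compound 4 is thus expected to give about 160000 nM in this assay, most likely between 60000 nM and 400000 nM.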

Compound 4, concentration for 50% growth inhibition: 100000 nM
Beside the measured number, compound 4's estimate is 1.6-fold (0.20 log units) above it; measured number inside the range.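

On the second core, the same exchange of the 2,5-dihydroxyphenyl group for the non-aromatic ring gives a 1.1-fold higher number from compound 2 to compound 4 (0.03 log units; within the scatter) in this assay, so here too the change has no clear effect on the number. Set beside the step on the first core, the second step tells the same story, and the two cannot be told apart: the same change on two cores in this assay, a 1.8-fold higher number (0.26 log units; within the scatter) from compound 1 to compound 3 and a 1.1-fold higher number (0.03 log units; within the scatter) from compound 2 to compound 4, 1.7-fold (0.24 log units) apart, within the scatter of two such steps This shows that, between these two cores, the small size of the step carried over, but it rests on only two pairs, does not show that the step would stay small on any other core, and says nothing about why the change matters so little.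

The compounds shown leave open how a third group at this place, such as a 2,5-dimethoxyphenyl group or a carboxylic acid, would compare with the 2,5-dihydroxyphenyl group and the ring that replaces it. They also leave open whether the step stays this small on a core that carries only one of the two differences between these cores, the chlorine or the acetyl group.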